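Extending the side chain of compound 1 with a diethylamino group

A few compounds are considered here, and "the series" means these few. Any claim that something is new, unique, unknown or untested is made for them only; others in the source may bear on it.

Compound 1, with the structure `CCn1c(N)c(-c2nc3ccccc3[nH]2)c2nc(C#N)c(C#N)nc21`, is tested in a functional assay on K562 cells (Homo sapiens) for antiproliferative activity, read by MTT assay, with a stated time of 48 h; a lower number here means a stronger inhibitor, a higher number a weaker inhibitor. In this assay compound 1 gives > 50000 nM, which is a limit of the assay rather than a number, so compound 1 stands only at that limit (the limit of > 50000 nM in this assay, at which 1 of the 3 values shown sits). Two related compounds carry an amine-bearing group at the same place on the chain. Compound 2, `N#Cc1nc2c(-c3nc4ccccc4[nH]3)c(N)n(CCN3CCCC3)c2nc1C#N`, gives 6480 nM in this assay, and compound 3, `CN1CCN(CCCn2c(N)c(-c3nc4ccccc4[nH]3)c3nc(C#N)c(C#N)nc32)CC1`, gives 1260 nM. The steps are an at least 7.7-fold lower number from compound 1 to compound 2 (0.88 log units; beyond the scatter) and an at least 39-fold lower number from compound 1 to compound 3 (1.59 log units; beyond the scatter), and between the two amines the step is a 5.1-fold lower number from compound 2 to compound 3 (0.71 log units; beyond the scatter).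

Compound 4, `CCN(CC)CCCCn1c(N)c(-c2nc3ccccc3[nH]2)c2nc(C#N)c(C#N)nc21`, differs from compound 1 by 2-(diethylamino)ethyl in place of hydrogen on a saturated chain carbon, two bonds along the chain from an aromatic nitrogen. Among the compounds with values here, the change most resembles the one from compound 1 to compound 2, both placing a basic amine on the chain, so compound 4 is expected to move well away from the limit of compound 1, with a step of about an at least 10-fold lower number from compound 1 to compound 4 (1.00 log units; beyond the scatter). Compound 4 is therefore estimated at 5000 nM in this assay, within a range from 1500 nM to 20000 nM.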

Compound 4, half-maximal inhibitory concentration: 1440 nM
Beside the measured number, compound 4's estimate is 3.5-fold (0.54 log units) above it, outside the stated range (below it).
By their numbers in this assay, from the lowest: compounds 3 and 4 (each within the scatter of the next); then compound 2. At a limit, above all of these: compound 1.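

In this assay, placing 2-(diethylamino)ethyl on the chain of compound 1 gives an at least 34-fold lower number from compound 1 to compound 4 (1.54 log units; beyond the scatter), so a chain ending in an open-chain amine can also carry a large gain. Going by these compounds, the true size of that step stays unknown, as compound 1 gives only a limit of the assay: the limit of > 50000 nM in this assay, at which 1 of the 4 values shown sits. Compound 4 also shows that a ring on the amine is not required for this level of activity, with a 1.1-fold higher number from compound 3 to compound 4 (0.06 log units; within the scatter), while a 4.5-fold lower number from compound 2 to compound 4 (0.65 log units; beyond the scatter).

Compounds 2, 3 and 4 differ in both the amine and the chain length, so the effects of the two changes cannot be separated. A 4-(pyrrolidin-1-yl)butyl chain would test the amine at a fixed length, and a butyl chain ending in a hydroxyl group would test whether the amine is needed at all.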